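Thiazolidinone amides: aryl swap on the ring nitrogen

The source may hold more compounds than are shown below. What is called first, only, known or untested is meant among the compounds shown, and "the series" means these compounds.

Three compounds of this series carry a measured value in a functional assay on HOS-TE85 cells (Homo sapiens) for inhibition, read by CCK-8 assay, with a stated time of 72 h; a lower number here means a stronger inhibitor, a higher number a weaker inhibitor. Compound 1 `CC1SC(c2cccc(C(=O)NCCCCc3ccc(Cl)cc3)c2)N(c2cccc(C3CC3)c2)C1=O` gives 932 nM in this assay. Compound 2 `C#Cc1cccc(N2C(=O)CSC2c2cccc(C(=O)NCCCCc3ccccc3)c2)c1` gives 149 nM in this assay. Compound 3 `O=C(NCCCCn1cccn1)c1cccc(C2SCC(=O)N2c2cc(Cl)ccn2)c1` gives 36.4 nM in this assay. Among these three numbers compound 2 stands second highest: compound 3 sits nearest, with a lower number beyond the scatter, and compound 1 sits furthest, with a higher number beyond the scatter.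

Compound 4 `O=C(NCCCCc1ccccc1)c1cccc(C2SCC(=O)N2c2ccccc2F)c1` has not been measured. It differs from compound 2 as follows (2-fluorophenyl in place of 3-ethynylphenyl on an amide-type nitrogen in a ring). Within the data shown here, no measured pair differs in one place, so this change has no precedent here, and the three measured compounds all differ from one another at more than one point.

The expected step is modest, within or close to the scatter, with no firm direction. The estimate for compound 4 in this assay is 200 nM, within 60 nM to 650 nM. The step this estimate means is expected to be a 1.3-fold higher number from compound 2 to compound 4 (0.13 log units; within the scatter).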

Compound 4, half-maximal inhibitory concentration in the HOS-TE85 assay: 34.1 nM
The estimate for compound 4 lay 5.9-fold (0.77 log units) above the measured number; the whole stated range lies above it.
By their numbers in the HOS-TE85 assay, from the lowest: compounds 4 and 3 (each within the scatter of the next); then compound 2; then compound 1.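

Among these compounds, the aryl group on the amide-type nitrogen is the first place where a single change can be read, and in the HOS-TE85 assay it is not silent: a 4.4-fold lower number from compound 2 to compound 4 (0.64 log units; beyond the scatter), with 2-fluorophenyl in place of 3-ethynylphenyl. In a physicochemical assay for solubility, read by turbidimetry, measured as kinetic solubility, at pH 7.4 (on this read-out lower numbers stand for lower solubility and higher numbers for higher solubility), compound 2 gives 10000 nM and compound 4 gives 10000 nM, so this pair shows no change at the digits printed from compound 2 to compound 4 (within the scatter) on that read-out. No measurement shown gives a reason for the step in the cell assay.

This one step cannot separate the departure of the ethynyl group from the arrival of the fluorine. An unsubstituted phenyl, 3-fluorophenyl or 2-chlorophenyl on the same nitrogen, with the rest of compound 4 kept, would help to tell these apart.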